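Methoxy to trifluoromethyl on the second aryl ring

The compounds below may be only part of what the source reports. "The series", "measured", "known", "first", "only" and "open" are said of these compounds alone.

The series shares one core, shown here as compound 1 `C=CCn1c(=O)/c(=C\c2cccc(F)c2)[nH]c(=O)/c1=C\c1ccccc1OC` and compound 2 `C=CCn1c(=O)/c(=C\c2ccccc2OC)[nH]c(=O)/c1=C\c1ccccc1OC`. In a functional assay on Huh-7 cells (Homo sapiens) for cytotoxicity, read by CCK-8 assay, with a stated time of 72 h (on this read-out lower numbers stand for stronger inhibition and higher numbers for weaker inhibition), compound 1 gives 27200 nM and compound 2 gives 21200 nM. For the measured compounds named here, the step of a 1.3-fold lower number from compound 1 to compound 2 (0.11 log units; within the scatter) is the only measured step, and it sits within the scatter, so compound 2 and compound 1 cannot be set apart on these numbers; they stand level with each other.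

Compound 3 `C=CCn1c(=O)/c(=C\c2ccccc2C(F)(F)F)[nH]c(=O)/c1=C\c1ccccc1OC` is not yet measured. It differs from compound 2 in one place: trifluoromethyl in place of methoxy on an aromatic carbon. Going by the values given here, no measured step touches this position; the single step from compound 1 to compound 2 concerns the other aryl ring, and it did not move the number beyond the scatter. Among the compounds with values here, there is therefore no measured step that bears on this change, and the series so far shows a read-out that has been insensitive to the one aryl substitution tried. On that basis the step from compound 2 to compound 3 in this assay is expected to stay within the scatter, that is a 1.1-fold higher number from compound 2 to compound 3 (0.05 log units; within the scatter), in no firm direction. For compound 3 the estimate is 24000 nM with a range from 8000 nM to 75000 nM.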

Compound 3, half-maximal inhibitory concentration: 9500 nM
For compound 3 the middle estimate is 2.5-fold (0.40 log units) above the measured one, and the stated range covers the measured number.
By their numbers in this assay, from the lowest: compound 3; then compounds 2 and 1 (each within the scatter of the next).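

In this assay, for the compounds shown here, this aryl position is no longer flat: 2-(trifluoromethyl)phenyl gives the first step beyond the scatter, with a 2.2-fold lower number from compound 2 to compound 3 (0.35 log units; beyond the scatter) as trifluoromethyl replaces methoxy on an aromatic carbon. The step of a 2.9-fold lower number from compound 1 to compound 3 (0.46 log units; beyond the scatter) points the same way and is also modest, whereas the earlier pair showed only a 1.3-fold lower number from compound 1 to compound 2 (0.11 log units; within the scatter) and could not be separated, so 3-fluorophenyl and 2-methoxyphenyl stand level while 2-(trifluoromethyl)phenyl stands apart from both. Nothing available on these compounds accounts for this shift, so the observation stays a plain difference in cytotoxicity read-out within three compounds.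

The compounds shown leave open whether the shift is particular to trifluoromethyl or would also appear with another group in that place, such as a chlorine atom, a nitrile, an amine or a carboxylic acid. They also leave open whether the same exchange on the second aryl ring, which stays 2-methoxyphenyl in all three compounds, would give a step of similar size.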